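Adding a fluorine to the strongest of two anilide amides

A few compounds are considered here, and "the series" means these few. Any claim that something is new, unique, unknown or untested is made for them only; others in the source may bear on it.

Two close relatives of the same core have been measured. Compound 1 `CCNC(=O)c1cc(Oc2ccc(NC(=O)c3cc4cccnc4n(-c4ccccc4F)c3=O)cc2)ccn1` and compound 2 `CCCNC(=O)c1cc(Oc2ccc(NC(=O)c3cc4cccnc4n(-c4ccccc4)c3=O)cc2)ccn1` were tested in a functional assay on A549 cells (Homo sapiens) for antiproliferative activity, read by MTT assay, with a stated time of 72 h; a lower number here means a stronger inhibitor, a higher number a weaker inhibitor; in that assay compound 1 gives 490 nM, and compound 2 gives 95 nM. Compound 2 therefore stands at the lower of the two numbers, the stronger inhibitor, and its gap to compound 1 lies beyond the usual scatter. The two compounds differ in two places at once, so their values alone cannot say which of the two changes carries the gap.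

Compound 3 `CCCNC(=O)c1cc(Oc2ccc(NC(=O)c3cc4cccnc4n(-c4ccccc4F)c3=O)cc2)ccn1` has not yet been measured. It is built from compound 2 by a single change: fluoro in place of hydrogen on an aromatic carbon. For the measured compounds named here, no pair of measured compounds shows this change in isolation, so its effect can only be estimated. Going by the values given here, since the one measured compound bearing this fluorine, compound 1, sits at the weaker end with 490 nM, a modest weakening is expected rather than a gain, though a null result within the scatter is equally plausible. For compound 3 the expected step is a 2.1-fold higher number from compound 2 to compound 3 (0.32 log units; beyond the scatter). Compound 3 is estimated to give about 200 nM in this assay, with a likely range from 60 nM to 650 nM.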

Compound 3, half-maximal inhibitory concentration: 150 nM
Estimate against measurement, compound 3: 1.3-fold (0.12 log units) above, within the range that was stated.
By their numbers in this assay, from the lowest: compounds 2 and 3 (each within the scatter of the next); then compound 1.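

In this assay, replacing phenyl with 2-fluorophenyl gives a 1.6-fold higher number from compound 2 to compound 3 (0.20 log units; within the scatter), so the fluoro on this aromatic carbon, ortho to a large group, makes no difference that can be read in this series. For the compounds shown here, the other single change, methyl in place of hydrogen on a saturated chain carbon, two bonds along the chain from an amide-type nitrogen, gives a 3.3-fold lower number from compound 1 to compound 3 (0.51 log units; beyond the scatter), which means that of the two changes separating compound 1 and compound 2, only the one on the chain has a step beyond the scatter. Nothing shown explains why the chain change registers and the fluoro does not.

From the compounds shown here alone, the chain step has been read only with the fluoro present, so its size on the unsubstituted phenyl remains open, as does whether a butyl chain or a chain ending in an amine would continue the trend. Going by these compounds, it is also open whether a chlorine or a methoxy group in place of this fluoro would stay within the scatter of compound 2 or move the number further.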